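This account rests on a few compounds, and the source may have more. Where it says the series, first, only, none or still open, it means among the compounds named here.

Of the compounds shown here, two have been measured so far. Compound 1 `CCCCSC[C@H](NC(C)=O)C(=O)CCl` and compound 2 `CCCCCCCSC[C@H](NC(C)=O)C(=O)CCl` share one core and differ only in the length of a saturated chain attached to a sulfur. In a functional assay on MOLT-3 cells (Homo sapiens) (on this read-out higher numbers stand for weaker inhibition and lower numbers for stronger inhibition), compound 1 gives 5600 nM, and in this assay compound 2 gives 2500 nM, the lowest of the two numbers, with the step being a 2.2-fold lower number from compound 1 to compound 2 (0.35 log units; beyond the scatter).

Compound 3 `CCCCCCCCCSC[C@H](NC(C)=O)C(=O)CCl` continues in the same direction: it differs from compound 2 by ethyl in place of hydrogen on a saturated chain carbon, seven bonds along the chain from a sulfur, which again lengthens the saturated chain. Among the measured compounds shown here, the only measured step that bears on this change is the lengthening from compound 1 to compound 2, which was a 2.2-fold lower number from compound 1 to compound 2 (0.35 log units; beyond the scatter), a modest move toward stronger inhibition. A further lengthening is therefore expected to give at most a modest step in the same direction, or none beyond the scatter; the expected step is a 1.6-fold lower number from compound 2 to compound 3 (0.19 log units; within the scatter). Compound 3 is estimated at 1600 nM, in a range from 600 nM to 4500 nM.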

Compound 3, half-maximal inhibitory concentration: 6700 nM
Beside the measured number, compound 3's estimate is 4.2-fold (0.62 log units) below it; the measured number lies above the stated range.
By their numbers in this assay, from the lowest: compound 2; then compounds 1 and 3 (each within the scatter of the next).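

In this assay, ethyl in place of hydrogen on a saturated chain carbon, seven bonds along the chain from a sulfur, gives a 2.7-fold higher number from compound 2 to compound 3 (0.43 log units; beyond the scatter) and so reverses the move toward stronger inhibition seen in a 2.2-fold lower number from compound 1 to compound 2 (0.35 log units; beyond the scatter) on the shorter chains. Measured against the shortest chain, the result is a 1.2-fold higher number from compound 1 to compound 3 (0.08 log units; within the scatter) and leaves no net gain, so lengthening the chain helps only up to a point in this set, with compound 3 going against the earlier direction and compound 2 giving the lowest number of the three. Nothing measured here explains this reversal.

Where the turn lies remains open, since an octyl chain would fall between compound 2 and compound 3. From the compounds shown here alone, it is also open whether a chain carrying an amine or a carboxylic acid would behave like these plain saturated chains.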